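This account rests on a few compounds, and the source may have more. Where it says the series, first, only, none or still open, it means among the compounds named here.

Compound 3 `COC(=O)CNCCCOc1ccc2cc(NC(=O)c3ccc(O)c(CC=C(C)C)c3)c(=O)oc2c1C` gives 1060 nM in a functional assay on SK-BR-3 cells (Homo sapiens) for antiproliferative activity (a lower number here means a stronger inhibitor, a higher number a weaker inhibitor), the highest of the three numbers here, though its gaps to compound 2 `CC(C)=CCc1cc(C(=O)Nc2cc3ccc(OCCCN(C)C(C)(C)C)c(C)c3oc2=O)ccc1O` at 880 nM and to compound 1 `CC(C)=CCc1cc(C(=O)Nc2cc3ccc(OCCCN(C)C(C)C)c(C)c3oc2=O)ccc1O` at 570 nM are small: a 1.2-fold higher number from compound 2 to compound 3 (0.08 log units; within the scatter) and a 1.9-fold higher number from compound 1 to compound 3 (0.27 log units; within the scatter). Compound 4 `CC(C)=CCc1cc(C(=O)Nc2cc3ccc(OCCCN(C)Cc4ccccc4)c(C)c3oc2=O)ccc1O` differs from compound 3 in one place: benzyl(methyl)amino in place of ((methoxycarbonyl)methyl)amino on a saturated chain carbon, three bonds along the chain from an oxygen on an aromatic ring. The measured steps that bear on this all swap groups at the same amine end of the chain, namely a 1.9-fold higher number from compound 1 to compound 3 (0.27 log units; within the scatter), a 1.2-fold higher number from compound 2 to compound 3 (0.08 log units; within the scatter) and a 1.5-fold higher number from compound 1 to compound 2 (0.19 log units; within the scatter), and none moved beyond the scatter. A similar outcome is therefore expected, with no step beyond the scatter: a 1.5-fold lower number from compound 3 to compound 4 (0.18 log units; within the scatter). Compound 4 is estimated at 700 nM, within a range of 250 nM to 2000 nM.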

Compound 4, half-maximal inhibitory concentration: 10700 nM
Compound 4: the middle estimate sits 15-fold (1.18 log units) below what was measured, outside the stated range (above it).
By their numbers in this assay, from the lowest: compounds 1, 2 and 3 (each within the scatter of the next); then compound 4.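

The amine end of the chain is less forgiving than the first three compounds suggested: benzyl(methyl)amino gives a 10-fold higher number from compound 3 to compound 4 (1.00 log units; beyond the scatter), and benzyl on the amine nitrogen gives a 12-fold higher number from compound 2 to compound 4 (1.08 log units; beyond the scatter) in place of tert-butyl and a 19-fold higher number from compound 1 to compound 4 (1.27 log units; beyond the scatter) in place of isopropyl. Among these four compounds, only the group carrying a six-membered aromatic ring stands apart from the rest. Nothing measured here gives a reason for this drop.

From the compounds shown here alone, whether the aromatic ring itself matters stays open. A cyclohexylmethyl group on the same amine nitrogen would test this, and a pyridylmethyl group would show what a ring nitrogen does.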